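The compounds below may be only part of what the source reports. "The series", "measured", "known", "first", "only" and "open" are said of these compounds alone.

Measured compounds and values in a functional assay on HOP-92 cells (Homo sapiens) for inhibition, read by sulforhodamine B assay, with a stated time of 48 h; a lower number here means a stronger inhibitor of growth, a higher number a weaker inhibitor of growth:
compound 1 `COc1ccc(-c2ccc(-c3ccc(C(=N)N)cc3)s2)cc1`: 750 nM
compound 2 `N=C(N)c1ccc(-c2ccc(-c3cc(Cl)cc(Cl)c3)s2)cc1`: 1710 nM
compound 3 `N=C(N)c1ccc(-c2ccc(-c3ccc(F)cc3)s2)cc1`: 1540 nM

Among these three, compound 1 gives the lowest number. The nearest to it is compound 3, reached by a 2.1-fold higher number from compound 1 to compound 3 (0.31 log units; beyond the scatter). Going by the values given here, no single-point step connects compound 1 to compound 2. Compound 2 lies further off, and its value of 1710 nM simply shows that it sits at the higher end of the three.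

The compound whose measurement is awaited is compound 4 `COc1ccc(-c2ccc(-c3ccc(C(=N)N)c(F)c3)s2)cc1`. It differs from compound 1 in one place:
fluoro in place of hydrogen on an aromatic carbon

Among the compounds with values here, only one measured step speaks to this change, and only indirectly: a 2.1-fold higher number from compound 1 to compound 3 (0.31 log units; beyond the scatter), where a fluoro replaced a methoxy. In compound 4 the methoxy of compound 1 is kept and a fluoro is added elsewhere, so that step is not the same change. Within the data shown here, no measured pair shows a fluoro entering in place of hydrogen at this position. The expectation is therefore a small step, if any, with a slight lean toward a higher number given the modest rise seen when fluoro replaced methoxy. Compound 4 is estimated at 950 nM, within 450 nM to 2000 nM, which is expected to mean a 1.3-fold higher number from compound 1 to compound 4 (0.10 log units; within the scatter).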

Compound 4, concentration for 50% growth inhibition: 1380 nM
Compound 4: the middle estimate sits 1.5-fold (0.16 log units) below what was measured; the measured number falls inside the stated range.
By their numbers in this assay, from the lowest: compounds 1, 4, 3 and 2 (each within the scatter of the next, the first and the last beyond it).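

Going by these compounds alone, the earlier compounds differ only in the group that stands where compound 1 carries its methoxy, so they say nothing about the six-membered aromatic ring of carbon only that holds the group of 3 heavy atoms. Within the data shown here, compound 4 gives the first reading on that ring, with a fluoro ortho to a group of 3 heavy atoms and meta to a large group. In this assay this change gives a 1.8-fold higher number from compound 1 to compound 4 (0.26 log units; within the scatter) and so shows that this single added atom leaves the number at a level that cannot be told apart from that of compound 1. Nothing among the data shown accounts for this outcome.

It remains open whether this position would read the same with a group larger than one atom, such as a hydroxyl, an amine or a nitrile, since fluoro is the only replacement for hydrogen shown here. Also open, going by these compounds, is whether the same fluoro would read alike when the methoxy of compound 1 gives way to the fluoro of compound 3 or to the two chloro groups of compound 2.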